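Moving the methoxy group around the sulfonamide aryl ring

The source may report more compounds than this note shows. Statements on the series, on what has been measured and on what is new or still open speak of the compounds shown alone.

Three compounds share one core, a sulfonamide carrying an aryl group on its nitrogen, and are compared in a functional assay on M21 cells (Homo sapiens) for antiproliferative activity, read by sulforhodamine B assay, with a stated time of 48 h; a lower number here means a stronger inhibitor, a higher number a weaker inhibitor. Compound 1 `Cc1ccc(NS(=O)(=O)c2ccc(N3CCNC3=O)cc2)cc1C` gives 94 nM in this assay. Compound 3 `COc1cc(NS(=O)(=O)c2ccc(N3CCNC3=O)cc2)cc(OC)c1` gives 60 nM in this assay, and the two numbers lie within the scatter of each other, so no order can be read between them. Compound 2 `CC(C)(C)c1cc(NS(=O)(=O)c2ccc(N3CCNC3=O)cc2)cc(C(C)(C)C)c1` gives only a limit, > 1000 nM, which is the limit of > 1000 nM in this assay, at which 1 of the 3 values shown sits. Among the numbers shown, compound 1 therefore holds the higher of the two, with compound 3 nearest to it.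

Compound 4 `COc1ccccc1NS(=O)(=O)c1ccc(N2CCNC2=O)cc1` is the next step from compound 1. The change is 2-methoxyphenyl in place of 3,4-dimethylphenyl on a sulfonamide nitrogen. Both neighbours with small aryl substituents give similar numbers, and only the bulky compound 2 reaches the limit, so the step from compound 1 to compound 4 is expected to stay small, a 1.6-fold higher number from compound 1 to compound 4 (0.20 log units; within the scatter), with no direction beyond the scatter. Compound 4 is expected to give about 150 nM in this assay, likely between 50 nM and 500 nM.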

Compound 4, half-maximal inhibitory concentration: 300 nM
Estimate against measurement, compound 4: 2.0-fold (0.30 log units) below; the range from low to high includes it.
By their numbers in this assay, from the lowest: compounds 3 and 1 (each within the scatter of the next); then compound 4. At a limit, above all of these: compound 2.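

Replacing 3,4-dimethylphenyl with 2-methoxyphenyl on the sulfonamide nitrogen gives a 3.2-fold higher number from compound 1 to compound 4 (0.50 log units; beyond the scatter) in this assay. This shows that a small aryl group at this position does not by itself keep the number close to that of compound 1. Both groups have 8 heavy atoms, so heavy-atom count alone does not settle the result here. The substituents and their places on the ring change together. This one step cannot be tied to either. No measurement shown gives a reason for the step.

From the compounds shown here alone, it remains open how 3-methoxyphenyl or 4-methoxyphenyl would compare with 2-methoxyphenyl at this position. The effect of an aryl ring carrying a dimethylamino group or a carboxylic acid is also unknown.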